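The compounds below may be only part of what the source reports. "The series", "measured", "known", "first", "only" and "open" are said of these compounds alone.

Measured compounds:
compound 1, `CCOC(=O)/C=C/c1ccncc1-c1ccc2c(ccn2C)c1`: 144 nM
compound 2, `CC(C)[C@@H](NC(=O)/C=C/c1ccncc1-c1ccc2ccccc2c1)C(=O)O`: "not determined" (no result reported)
compound 3, `Cn1ncc2cc(-c3cnccc3/C=C/C(=O)N3CCOCC3)ccc21`: 356 nM

Three compounds share a common core and were tested in an assay on a protein complex for inhibition of CDK8/Cyclin C (Homo sapiens), with a stated time of 1 h; a higher number here means a weaker inhibitor, a lower number a stronger inhibitor. Compound 1 gives 144 nM in this assay, and compound 3 gives 356 nM; these two values lie within the usual scatter of each other. Compound 2, in contrast, has no number at all: in this assay compound 2 is recorded as "not determined" (no result reported), so it stands nowhere on the scale and offers no anchor of its own.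

The account now turns from compound 2 to compound 4, `COC(=O)/C=C/c1ccncc1-c1ccc2ccccc2c1`. The change between them is methoxy in place of (1-carboxy-2-methylpropyl)amino on a carbonyl carbon. Among the compounds with values here, no measured step exists for this pair, so no size or direction of change can be taken from the data; the expectation for compound 4 rests only on compound 1 and compound 3, which carry other groups on the same carbonyl carbon. Of these two, compound 1 gives 144 nM and compound 3 gives 356 nM. Compound 4 is therefore expected to fall near those values, estimated at 250 nM with a range from 80 nM to 800 nM.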

Compound 4, half-maximal inhibitory concentration: 40.6 nM
Beside the measured number, compound 4's estimate is 6.2-fold (0.79 log units) above it, outside the stated range (below it).
By their numbers in this assay, from the lowest: compound 4; then compound 1; then compound 3.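

In this assay no step can be read from compound 2 to compound 4. The compounds shown leave open how far, and in which direction, methoxy in place of (1-carboxy-2-methylpropyl)amino on the carbonyl carbon shifts the value. No evidence at hand bears on this result.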